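The source may hold more compounds than are shown below. What is called first, only, known or untested is meant among the compounds shown, and "the series" means these compounds.

Compound 1 `Cc1c(Cc2ccc(Cl)cc2)c(=O)oc2cc(OCC(O)CN3CCC(C(N)=O)CC3)ccc12`: 40000 nM
Compound 2 `Cc1c(Cc2ccc(Br)cc2)c(=O)oc2cc(OCC(O)CN3CCC(C(N)=O)CC3)ccc12`: > 100000 nM (a limit of the assay, not a number)
Compound 3 `COc1ccc(Cc2c(C)c3ccc(OCC(O)CN4CCC(C(N)=O)CC4)cc3oc2=O)c(Br)c1`: 44400 nM

In an ADME assay on A549 cells (Homo sapiens) for cytotoxicity, read by CellTiter-Glo (a lower number here means that less compound is tolerated, a higher number that more compound is tolerated), compound 3 gives 44400 nM. Its nearest neighbour is compound 1, and the change is a 1.1-fold higher number from compound 1 to compound 3 (0.05 log units; within the scatter), so the two sit level. Compound 2 stands at a limit, and that limit is the limit of > 100000 nM in this assay, at which 1 of the 3 values shown sits. The gap on that side is an at least 2.2-fold lower number from compound 2 to compound 3 (0.35 log units; beyond the scatter).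

Compound 4 `Cc1c(Cc2cccc3ccccc23)c(=O)oc2cc(OCC(O)CN3CCC(C(N)=O)CC3)ccc12` has not yet been measured. It carries naphthalen-1-yl in place of 2-bromo-4-methoxyphenyl on a saturated chain carbon bound to an aromatic carbon. Within the data shown here, no measured compound carries naphthalen-1-yl, so no step shows this exchange directly. The closest guidance comes from other exchanges at the same place. Replacing the group of compound 1 with that of compound 3 gave a 1.1-fold higher number from compound 1 to compound 3 (0.05 log units; within the scatter), while the exchange of chloro for bromo gave an at least 2.5-fold higher number from compound 1 to compound 2 (0.39 log units; beyond the scatter). One step therefore stays within the scatter, and the other is at least modest, with its full size hidden by the limit.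

With no clear direction to follow, no shift beyond the scatter is expected in this assay. The expected change is a 1.0-fold higher number from compound 3 to compound 4 (0.01 log units; within the scatter). The estimated value for compound 4 is 45000 nM. The expected range for compound 4 runs from 20000 nM to 100000 nM.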

Compound 4, half-maximal cytotoxic concentration: 42400 nM
Beside the measured number, compound 4's estimate is 1.1-fold (0.03 log units) above it; the range from low to high includes it.
By their numbers in this assay, from the lowest: compounds 1, 4 and 3 (each within the scatter of the next). At a limit, above all of these: compound 2.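

In this assay, naphthalen-1-yl, which has 2 six-membered aromatic rings of carbon only, holds level with the single-ring groups at this place on a saturated chain carbon bound to an aromatic carbon: a 1.0-fold lower number from compound 3 to compound 4 (0.02 log units; within the scatter), and a 1.1-fold higher number from compound 1 to compound 4 (0.03 log units; within the scatter). The earlier compounds shown here all carried a halogen on the aromatic ring, so compound 4 adds that a group with no bromine, chlorine or oxygen can give a number within the scatter of compound 1 and compound 3. Compound 2 now stands apart from three compounds rather than two, with an at least 2.3-fold lower number from compound 2 to compound 4 (0.37 log units; beyond the scatter), and its value is a limit of the assay, not a number: the limit of > 100000 nM in this assay, at which 1 of the 4 values shown sits.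

The compounds shown leave open whether the 4-bromophenyl group of compound 2 is a lone exception among these groups, since its true value and the value of plain phenyl at this place are both unknown. Also open, going by these compounds, is how the number in this assay would respond to an amine or a carboxylic acid on the aromatic ring of this group.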